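The source may hold more compounds than are shown below. What is called first, only, known or untested is meant among the compounds shown, and "the series" means these compounds.

Compound 1, `COc1cccc(OC)c1OCCNC[C@H]1Oc2ccccc2O[C@H]1C1CCCCC1` — 631 nM
Compound 2, `COc1cccc(OC)c1OCCNC[C@H]1Oc2ccccc2O[C@H]1c1ccc(Cl)cc1` — 81.3 nM

In a functional assay for antagonist activity at Adrenergic receptor alpha-1 (Rattus norvegicus) (a higher number here means weaker binding, a lower number tighter binding), compound 2 gives 81.3 nM, the lowest of the two numbers measured; compound 1 gives 631 nM. Within the data shown here, the only measured step, a 7.8-fold lower number from compound 1 to compound 2 (0.89 log units; beyond the scatter), exchanged one ring on a saturated ring carbon for another and moved the number well beyond the scatter. Compound 3, `CCc1ccc([C@@H]2Oc3ccccc3O[C@@H]2CNCCOc2c(OC)cccc2OC)cc1`, differs from compound 2 on that same aromatic ring: ethyl in place of chloro on an aromatic carbon, so that 4-chlorophenyl becomes 4-ethylphenyl. Among the measured compounds shown here, no measured step exchanges one substituent for another on this ring, so the single known step bears on it only loosely, showing that this part of the molecule can shift the number. With no donors or acceptors added or lost, no change beyond the scatter is expected, and the step is estimated as a 1.2-fold higher number from compound 2 to compound 3 (0.09 log units; within the scatter). Compound 3 is therefore expected to give about 100 nM, within a range from 40 nM to 250 nM.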

Compound 3, dissociation constant: 58.9 nM
Compound 3: middle estimate off by 1.7-fold (0.23 log units), on the high side; low and high end bracket the measured number.
By their numbers in this assay, from the lowest: compounds 3 and 2 (each within the scatter of the next); then compound 1.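

Ethyl in place of chloro on this aromatic carbon gives a 1.4-fold lower number from compound 2 to compound 3 (0.14 log units; within the scatter) in this assay, so this assay does not separate these two substituents, even though one is a single chlorine atom and the other a group of two carbons. Compared with the cyclohexyl compound, the 4-ethylphenyl group gives an 11-fold lower number from compound 1 to compound 3 (1.03 log units; beyond the scatter), which shows that the lower number seen with 4-chlorophenyl does not depend on the chlorine itself. No measurement here explains why the two substituents read alike or why either aromatic ring differs from cyclohexyl.

On these data alone, it remains open whether an amine, a carboxylic acid or a longer chain such as butyl at this carbon would also leave the number unchanged. An unsubstituted phenyl ring is also missing from the compounds shown, so what either substituent contributes relative to hydrogen remains unknown.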